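Taking the Hydroxy Group off Compound 2

The compounds below may be only part of what the source reports. "The series", "measured", "known", "first", "only" and "open" are said of these compounds alone.

Compound 1 `O=C(Nc1ccc(Sc2nc3ccccc3s2)c(Cl)c1)c1cccc(Br)c1`: > 100000 nM (a limit)
Compound 2 `O=C(Nc1ccc(Sc2nc3ccccc3s2)cc1)c1cccc(Br)c1O`: 71000 nM
Compound 3 `O=C(Nc1ccc(Sc2nc3ccccc3s2)cc1)c1cccc(Br)c1`: not yet measured

For the measured compounds named here, in an ADME assay on HEK293 cells (Homo sapiens) for cytotoxicity, read by reporter gene assay and resazurin assay, with a stated time of 48 h (on this read-out higher numbers stand for lower toxicity in this test and lower numbers for higher toxicity in this test), compound 2 gives 71000 nM, the only exact number so far. Compound 1 reads > 100000 nM, which is a limit of the assay and not a number. Compound 3 carries hydrogen in place of hydroxy on an aromatic carbon of compound 2, ortho to a bromo group (hydrogen in place of hydroxy on an aromatic carbon). Going by the values given here, no measured pair shows this change, so only a modest rise, towards lower toxicity, is expected. The estimated change is a 1.3-fold higher number from compound 2 to compound 3 (0.10 log units; within the scatter). Compound 3 is expected near 90000 nM, with an estimated range from 40000 nM to 200000 nM.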

Compound 3, half-maximal cytotoxic concentration: 74000 nM
For compound 3 the middle estimate is 1.2-fold (0.09 log units) above the measured one, and the stated range covers the measured number.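

In this assay, taking the hydroxy group off the 3-bromo-2-hydroxyphenyl group gives a 1.0-fold higher number from compound 2 to compound 3 (0.02 log units; within the scatter) so at this position, ortho to the bromo group, hydroxy and hydrogen read alike. Hydrogen in place of chloro gives an at least 1.3-fold lower number from compound 1 to compound 3 (0.13 log units; that floor lies within the scatter) and that step is only a floor. Its true size stays unknown because compound 1 reads as a limit of the assay and not a number: the limit of > 100000 nM in this assay, at which 1 of the 3 values shown sits.

On these data alone, whether an amine, a carboxylic acid or a methoxy group at the hydroxy position would read the same stays open. The shared core with a different group in place of bromo is open too.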